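The source may report more compounds than this note shows. Statements on the series, on what has been measured and on what is new or still open speak of the compounds shown alone.

Working notes on the series.

Compound 3 `COc1ncc(-c2nc(C(F)(F)F)sc2N2CCN(C(=O)Cn3nc(C)nc3C)[C@H](C)C2)cn1` carries the same core as compound 1 `COc1ncc(-c2nc(C(F)(F)F)sc2N2CCN(C(=O)Cn3cnc4cccnc43)[C@H](C)C2)cn1` and compound 2 `CCOc1ncc(-c2nc(C(F)(F)F)sc2N2CCN(C(=O)Cn3cc(Cl)cn3)[C@H](C)C2)cn1`, differing in the heteroaryl attached to the acetamide. In a functional assay on CHO-K1 cells for antagonist activity at C-X-C chemokine receptor type 3 (Homo sapiens), read by FLIPR, with a stated time of 10 min (on this read-out lower numbers stand for stronger inhibition and higher numbers for weaker inhibition), compound 1 gives 3.8 nM, compound 2 gives 5.1 nM and compound 3 gives 25 nM. Within the data shown here, compound 3 therefore stands at the weak end of the three numbers, and the one measured step that reaches it, a 6.6-fold higher number from compound 1 to compound 3 (0.82 log units; beyond the scatter), is the swap of the acetamide heteroaryl.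

Compound 4 `Cc1nc(C)n(CC(=O)N2CCN(c3sc(C(F)(F)F)nc3-c3cnc(C4CC4)nc3)C[C@H]2C)n1` is not yet measured. It differs from compound 3 in one place: cyclopropyl in place of methoxy on an aromatic carbon, the change reading at the ring level as 2-methoxypyrimidin-5-yl to 2-cyclopropylpyrimidin-5-yl. Among the measured compounds shown here, no measured step touches this position; the only step recorded, from compound 1 to compound 3, concerns the other end of the molecule. Compound 1 and compound 2 carry methoxy and ethoxy on that ring, but they also differ elsewhere, so their two values say nothing clean about the substituent on its own.

For the measured compounds named here, with no step to lean on, the expectation for compound 4 is a change near no change at the digits printed from compound 3 to compound 4 (within the scatter), that is none beyond the scatter. The estimate for compound 4 in this assay is 25 nM, with a range from 7 nM to 90 nM.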

Compound 4, half-maximal inhibitory concentration: 3.5 nM
Estimate against measurement, compound 4: 7.1-fold (0.85 log units) above, outside the stated range (below it).
By their numbers in this assay, from the lowest: compounds 4, 1 and 2 (each within the scatter of the next); then compound 3.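

The change from 2-methoxypyrimidin-5-yl to 2-cyclopropylpyrimidin-5-yl gives this end of the molecule its first clean step in this assay: a 7.1-fold lower number from compound 3 to compound 4 (0.85 log units; beyond the scatter), with the acetamide heteroaryl held constant. Among these compounds, until now the only single-place step was a 6.6-fold higher number from compound 1 to compound 3 (0.82 log units; beyond the scatter), at the acetamide heteroaryl, whereas this result shows that the substituent on an aromatic carbon between two ring nitrogen atoms also moves the number beyond the scatter. The change swaps a group with one hydrogen-bond acceptor for a ring of carbon only, but nothing measured here accounts for the step.

The compounds shown leave open whether the three-membered ring itself matters, or whether an open chain such as isopropyl, or an amine such as dimethylamino, on the same carbon would give a similar number. They also leave open whether the step carries over when the dimethyl-substituted heteroaryl of compound 3 is replaced by the acetamide heteroaryl of compound 1 or compound 2.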